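The source may hold more compounds than are shown below. What is called first, only, known or untested is meant among the compounds shown, and "the series" means these compounds.

Measured compounds:
- compound 1 `NS(=O)(=O)Oc1ccc2c(c1)CN(C(=O)c1ccc(N3CCC(N4CCCCC4)CC3)cc1)CC2` gives 53.7%
- compound 2 `CCN(Cc1cccnc1)c1ccc(C(=O)N2CCc3ccc(OS(N)(=O)=O)cc3C2)cc1` gives 85.2%
- compound 3 `CCN(Cc1ccncc1)c1cccc(C(=O)N2CCc3ccc(OS(N)(=O)=O)cc3C2)c1` gives 52.8%

All three share one core and were tested in an assay on HEK293 cells for inhibition of Steryl-sulfatase (Homo sapiens), tested at 1 uM; on this read-out lower numbers stand for a weaker effect and higher numbers for a stronger effect at the one concentration tested. Compound 3 has the lowest number of the three, but its value sits close to that of compound 1, a gap that lies within the usual scatter of repeated measurements, so the two cannot be told apart. Compound 2 stands well above compound 3, a gap that lies beyond the scatter.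

Compound 4 `CC(C)CCN(CCC(C)C)c1cccc(C(=O)N2CCc3ccc(OS(N)(=O)=O)cc3C2)c1` has not yet been measured in this assay. It differs from compound 3 in one place: diisopentylamino in place of ethyl((pyridin-4-yl)methyl)amino on an aromatic carbon. The group that enters has no ring and one fewer hydrogen-bond acceptor than the group that leaves, while the rest of the molecule stays the same.

For the measured compounds named here, no pair of measured compounds differs in exactly this way, so there is no measured step to lean on. Given that, the expectation for compound 4 is a number near that of compound 3, with a step that may be upward but is more likely to stay within the scatter than to go beyond it, estimated as a number 5.2 percentage points higher from compound 3 to compound 4 (within the scatter). Compound 4 is therefore estimated at 58%, with a range from 35% to 80%.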

Compound 4, a percentage reported as inhibition, at one concentration (the size of the read-out at that concentration, not a potency): 75.9%
Beside the measured number, compound 4's estimate is 17.9 percentage points below it; the measured number falls inside the stated range.
By their numbers in this assay, from the lowest: compounds 3 and 1 (each within the scatter of the next); then compounds 4 and 2 (each within the scatter of the next).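

In this assay, for the compounds shown here, the exchange of ethyl((pyridin-4-yl)methyl)amino for diisopentylamino, on an aromatic carbon meta to a large group, gives a number 23.1 percentage points higher from compound 3 to compound 4 (beyond the scatter), the first measured step at this position. It shows that the group placed here can change the read-out by more than the usual scatter of repeated measurements. The entering group has no ring, so at this position the pyridine ring of the leaving group is not required for a high number, and an open-chain group with one fewer hydrogen-bond acceptor does better in this comparison. Nothing available explains why the number rises, so the step remains an observation without a known cause.

This single exchange alters the ring, the hydrogen-bond acceptor count and the chains together, so it cannot show which of these changes matters. A diethylamino group or a plain primary amine at the same position would be needed to show whether the two long branched chains are required or whether simply removing the pyridine ring is enough.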